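Trading benzyloxy for methoxy in compound 3

The source may report more compounds than this note shows. Statements on the series, on what has been measured and on what is new or still open speak of the compounds shown alone.

In a functional assay on thoracic aorta (Rattus norvegicus, strain Wistar), with a stated time of 15 min (on this read-out lower numbers stand for an effect already at smaller amounts and higher numbers for an effect only at larger amounts of compound), compound 3 `Cc1ccc(S(=O)(=O)N(C)C(=O)NC(C)c2cc(Br)ccc2OCc2ccccc2)cc1` gives 67100 nM, the lower of the two actual numbers available. Compound 2 `CC(NC(=O)NS(=O)(=O)c1ccc(Cl)cc1)c1ccccc1OCc1ccccc1` gives 157000 nM, a higher number, and that gap lies beyond the usual scatter. Compound 1 `CCOc1ccc(F)cc1C(C)NC(=O)NS(=O)(=O)c1ccc(C)cc1` carries no benzyloxy group, and its value of > 300000 nM is a limit of the assay.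

The next compound, compound 4 `COc1ccc(Br)cc1C(C)NC(=O)N(C)S(=O)(=O)c1ccc(C)cc1`, departs from compound 3 by hydrogen in place of phenyl on a saturated chain carbon bound to an oxygen on an aromatic ring, turning benzyloxy into methoxy. Among the compounds with values here, no measured step isolates this change, so the expectation rests on little. Compound 3 at 67100 nM has the lowest number and keeps the benzyloxy group, although compound 2 keeps it too and sits higher. A moderate move towards larger amounts in this assay is therefore expected, with an estimated 2.2-fold higher number from compound 3 to compound 4 (0.35 log units; beyond the scatter). For compound 4 the estimated value is 150000 nM, with an expected range of 60000 nM to 350000 nM.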

Compound 4, half-maximal effective concentration: 19100 nM
Compound 4: the middle estimate sits 7.9-fold (0.90 log units) above what was measured; the whole stated range lies above it.
By their numbers in this assay, from the lowest: compound 4; then compound 3; then compound 2. At a limit, above all of these: compound 1.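

Turning benzyloxy into methoxy, with hydrogen in place of phenyl on a saturated chain carbon bound to an oxygen on an aromatic ring, gives a 3.5-fold lower number from compound 3 to compound 4 (0.55 log units; beyond the scatter) in this assay. Within the data shown here, no earlier pair differed in this one place, so this is the first direct reading of the change, and it shows that the phenyl is not needed for the effect at this place: removing it moves the number down, not up. The compounds shown offer no measurement that explains this step.

From the compounds shown here alone, the reading rests on a single pair, so whether the same change would hold with other groups elsewhere on the shared core stays open. Going by these compounds, how a hydroxy group or a longer chain such as butoxy would read at this place also remains unknown.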